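A Chain Extension Repeated on a Second Core

The source may hold more compounds than are shown below. What is called first, only, known or untested is meant among the compounds shown, and "the series" means these compounds.

Three compounds were measured in a functional assay on the whole organism (strain NMRI) with Mus musculus as the target, with a stated time of 60 min, at a dose of 20 mg/kg by the intraperitoneal route; on this read-out lower numbers stand for a weaker effect and higher numbers for a stronger effect at the one dose given:

Compound 1, `CSc1nnc(Cc2ccccc2Oc2ccccc2)[nH]1`, gave 147%.
Compound 2, `CCSc1nnc(Cc2ccccc2Oc2ccccc2)[nH]1`, gave 169%.
Compound 3, `CSc1nnc(Cc2ccc(Cl)cc2Oc2ccccc2F)[nH]1`, gave 136%.

Compound 1 and compound 2 differ by methyl in place of hydrogen on a saturated chain carbon bound to a sulfur, and this change gave a number 22 percentage points higher from compound 1 to compound 2 (beyond the scatter). Compound 3 carries a different core; the difference between the core of compound 1 and the core of compound 3 is not broken down here. Compound 3 sits lowest of the three in this assay, with its nearest neighbour compound 1 and compound 2 furthest from it.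

Compound 4, `CCSc1nnc(Cc2ccc(Cl)cc2Oc2ccccc2F)[nH]1`, has not yet been measured. It differs from compound 3 by methyl in place of hydrogen on a saturated chain carbon bound to a sulfur, the same change that separates compound 1 from compound 2, at the same place. Among the measured compounds shown here, compound 4 is therefore expected to show a step of a number 22 percentage points higher from compound 3 to compound 4 (beyond the scatter), resting on the single earlier instance a number 22 percentage points higher from compound 1 to compound 2 (beyond the scatter) and on the starting value of compound 3, 136%. For the measured compounds named here, only one prior pair exists, and that pair lies on another core. The expectation is held loosely. For compound 4 the estimate in this assay is 158%, with a range from 138% to 178%.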

Compound 4, a percentage reported as activity, at one dose (the size of the read-out at that dose, not a potency): 141%
Compound 4: middle estimate off by 17 percentage points, on the high side; the measured number falls inside the stated range.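

In this assay, extending methylsulfanyl to ethylsulfanyl on the core of compound 3 gave a number 5 percentage points higher from compound 3 to compound 4 (within the scatter), so the rise seen on the core of compound 1 was not repeated on this second core. Set side by side, the two steps do not agree: the same change on two cores in this assay, a number 22 percentage points higher (beyond the scatter) from compound 1 to compound 2 and a number 5 percentage points higher (within the scatter) from compound 3 to compound 4, 17 percentage points apart, beyond the scatter of two such steps. This shows that the change cannot be carried from one core to the other in this series with its size intact, but with a single pair on each core it does not show which difference between the two cores matters, nor how the change would read on any further core.

The compounds shown leave open how a propyl chain on the sulfur, one step longer than ethyl, would read in this assay on either core, and whether the two cores would then part further or come together. They also leave open what an amine in place of the ethylsulfanyl group would give on these cores.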